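The compounds below may be only part of what the source reports. "The series", "measured", "known", "first", "only" and "open" are said of these compounds alone.

Of the compounds shown here, three sharing one core have been measured in a functional assay on A549 cells (Homo sapiens) for cytotoxicity, read by MTT assay, with a stated time of 72 h; a higher number here means a weaker inhibitor, a lower number a stronger inhibitor. Compound 1 `CN1CCN(CCCCn2c3c(c4ccccc42)C(=O)c2c[n+]([O-])c4ccccc4c2C3=O)CC1` gives 90 nM, compound 2 `CCCN1CCN(CCCCn2c3c(c4ccccc42)C(=O)c2c[n+]([O-])c4ccccc4c2C3=O)CC1` gives 320 nM, and compound 3 `O=C1c2c[n+]([O-])c3ccccc3c2C(=O)c2c1c1ccccc1n2CCN1CCCCC1` gives 1080 nM. Compound 3 therefore has the highest number of the three and is the weakest inhibitor among them.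

Compound 4 `CN(C)CCCCn1c2c(c3ccccc31)C(=O)c1c[n+]([O-])c3ccccc3c1C2=O` has not been measured. It carries 2-(dimethylamino)ethyl in place of the piperidin-1-yl of compound 3, on a saturated chain carbon, two bonds along the chain from an aromatic nitrogen: 2-(dimethylamino)ethyl in place of piperidin-1-yl on a saturated chain carbon, two bonds along the chain from an aromatic nitrogen.

Going by the values given here, two measured steps concern that same place, each putting piperidin-1-yl where a longer group stood: a 12-fold higher number from compound 1 to compound 3 (1.08 log units; beyond the scatter), which is large, and a 3.4-fold higher number from compound 2 to compound 3 (0.53 log units; beyond the scatter), which is modest. Compound 4 reverses that kind of swap, so a lower number than that of compound 3 is expected. The comparison is loose, since the entering group here has no ring, unlike 2-(4-methylpiperazin-1-yl)ethyl and 2-(4-propylpiperazin-1-yl)ethyl. A further step, a 3.6-fold higher number from compound 1 to compound 2 (0.55 log units; beyond the scatter), shows that a change at the far end of the chain can also move the number.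

A modest drop is therefore expected in this assay, an estimated 3.6-fold lower number from compound 3 to compound 4 (0.56 log units; beyond the scatter). Compound 4 is estimated at 300 nM, with an expected range from 90 nM to 1000 nM.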

Compound 4, half-maximal inhibitory concentration: 310 nM
Compound 4: the middle estimate sits 1.0-fold (0.01 log units) below what was measured, within the range that was stated.
By their numbers in this assay, from the lowest: compound 1; then compounds 4 and 2 (each within the scatter of the next); then compound 3.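

The open-chain 2-(dimethylamino)ethyl, which has no ring, still gives a 3.5-fold lower number from compound 3 to compound 4 (0.54 log units; beyond the scatter) in this assay, so at this position a lower number than that of compound 3 does not depend on a piperazine ring in the entering group. Cut further out along the chain, on a saturated chain carbon, four bonds along the chain from an aromatic nitrogen, dimethylamino and 4-propylpiperazin-1-yl cannot be told apart, with a 1.0-fold lower number from compound 2 to compound 4 (0.01 log units; within the scatter), while 4-methylpiperazin-1-yl keeps the lowest number of the set, with a 3.4-fold higher number from compound 1 to compound 4 (0.54 log units; beyond the scatter). No measurement offered here explains any of these differences.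

The compounds shown leave open how much of the step to compound 4 belongs to the longer chain and how much to the end group, as 2-(piperidin-1-yl)ethyl and 4-(dimethylamino)butyl differ in both, and a 4-(piperidin-1-yl)butyl group would separate the two. They also leave open whether the chain needs an amine at its end at all, a question that a morpholine or a hydroxyl group in that place could address.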